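The source may hold more compounds than are shown below. What is called first, only, known or untested is meant among the compounds shown, and "the series" means these compounds.

Measured so far: compound 1 `N=C(NCCCc1c[nH]cn1)NCCC(c1ccc(Cl)cc1)c1ccccn1` gives 7.84 in a functional assay on cardiac atrium for agonist activity at histamine H2 receptor (Cavia porcellus); a lower number here means a less potent compound, a higher number a more potent compound, by a factor of ten per unit of this negative logarithm; compound 2 `N=C(NCCCc1c[nH]cn1)NCCC(c1ccccn1)c1cccs1` gives 7.16 in this assay.

Compound 2 stands lowest of the two, with compound 1 the nearer one at a number 0.68 log units lower from compound 1 to compound 2 (beyond the scatter). Compound 3 `N=C(NCCCc1c[nH]cn1)NCCC(c1ccccn1)c1ccccn1` has not yet been measured in this assay. It differs from compound 2 in one place: pyridin-2-yl in place of thiophen-2-yl on a saturated chain carbon bound to an aromatic carbon and a saturated chain carbon. Going by the values given here, only one measured step bears on this spot, the step of a number 0.68 log units lower from compound 1 to compound 2 (beyond the scatter), in which a six-membered ring gave way to a five-membered one. Going back to a six-membered ring here, a small rise is expected, a number 0.29 log units higher from compound 2 to compound 3 (within the scatter). Compound 3 is therefore estimated at 7.45, between 6.95 and 7.95.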

Compound 3, negative logarithm of the half-maximal effective concentration: 6.9
Compound 3: middle estimate off by 0.55 log units, on the high side; measured number outside the range, below it.
By their numbers in this assay, from the lowest: compounds 3 and 2 (each within the scatter of the next); then compound 1.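

The six-membered ring alone does not carry the number: swapping thiophen-2-yl for pyridin-2-yl gives a number 0.26 log units lower from compound 2 to compound 3 (within the scatter), while swapping 4-chlorophenyl for pyridin-2-yl gives a number 0.94 log units lower from compound 1 to compound 3 (beyond the scatter). Among these three compounds, ring size therefore does not sort the values, and only compound 1 stands apart. Nothing available explains this result.

Still open, going by these compounds, is whether the standing of compound 1 belongs to the chlorine or to the phenyl ring itself. A plain phenyl or a 4-fluorophenyl in this place would help separate the two.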